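This account rests on a few compounds, and the source may have more. Where it says the series, first, only, none or still open, it means among the compounds named here.

Compound 1 `Cc1ccc(NC(=O)Nc2cc(-c3ccccc3C(=O)O)ccc2Nc2ccccc2C(C)(C)C)cc1` gives 600 nM in an assay on HeLa cells for inhibition of Indoleamine 2,3-dioxygenase 1 (Homo sapiens), with stated times of 1 h and 18 h; on this read-out higher numbers stand for weaker inhibition and lower numbers for stronger inhibition. Compound 2 `Cc1ccc(NC(=O)Nc2cc(-c3ccccc3C(=O)O)ccc2N(C)c2ccccc2C(C)(C)C)cc1` reaches only the limit of this assay, > 1000 nM, and so stands as a limit rather than a number among the two results shown. For the measured compounds named here, the sole measured step, an at least 1.6-fold higher number from compound 1 to compound 2 (0.22 log units; that floor lies within the scatter), carries methyl in place of hydrogen on a nitrogen on an aromatic ring and is bounded by the limit of > 1000 nM in this assay, at which 1 of the 2 values shown sits. Going by the values given here, compound 3 `CCN(c1ccc(-c2ccccc2C(=O)O)cc1NC(=O)Nc1ccc(C)cc1)C1CCCC1` brings a different change, (cyclopentyl(ethyl)amino in place of methyl(2-(tert-butyl)phenyl)amino on an aromatic carbon), which no measured step covers. The expected step of an at least 1.1-fold lower number from compound 2 to compound 3 (0.04 log units; that floor lies within the scatter) is therefore set near no change, with wide uncertainty. Compound 3 is estimated at 900 nM, range 250 nM to 3000 nM.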

Compound 3, half-maximal inhibitory concentration: 23 nM
The estimate for compound 3 lay 39-fold (1.59 log units) above the measured number; measured number outside the range, below it.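

On the aromatic carbon ortho to the ((4-methylphenyl)carbamoyl)amino group, the 2-(tert-butyl)phenyl group is not needed for inhibition. Cyclopentyl(ethyl)amino in place of (2-(tert-butyl)phenyl)amino gives a 26-fold lower number from compound 1 to compound 3 (1.42 log units; beyond the scatter) in this assay, so a non-aromatic ring on this nitrogen gives much stronger inhibition than the aromatic one in compound 1. The same change gives an at least 43-fold lower number from compound 2 to compound 3 (1.63 log units; beyond the scatter), and that size is only a floor: the limit of > 1000 nM in this assay, at which 1 of the 3 values shown sits.

As far as these compounds go, it remains open whether the cyclopentyl or the ethyl accounts for the gain. Also open, from the compounds shown here alone, is whether cyclohexyl in place of cyclopentyl, or propyl in place of ethyl, would keep it.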